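The source may hold more compounds than are shown below. What is called first, only, known or untested is meant among the compounds shown, and "the series" means these compounds.

Working notes on the series, read in a functional assay on NCI-H1299 cells (Homo sapiens) for antiproliferative activity, read by fluorescence and resazurin assay, with a stated time of 48 h; on this read-out higher numbers stand for weaker inhibition and lower numbers for stronger inhibition. Compound 1 `Oc1ccc(-c2cn(Cc3ccccc3)cc2-c2ccc(O)cc2)cc1` gives 26900 nM. Compound 2 `COc1cccc(Cn2cc(-c3ccc(O)cc3)c(-c3ccc(O)cc3)c2)c1` gives 25300 nM. Compound 3 `COc1ccccc1Cn1cc(-c2ccc(O)cc2)c(-c2ccc(O)cc2)c1` gives 23100 nM, which places it level with the other two, since all three values lie within the scatter of one another.

Compound 4 `COc1ccc(Cn2cc(-c3ccc(O)cc3)c(-c3ccc(O)cc3)c2)cc1OC` is not yet measured. It has 3,4-dimethoxyphenyl in place of 2-methoxyphenyl on a saturated chain carbon bound to an aromatic nitrogen.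

Among the measured compounds shown here, no measured compound carries the 3,4-dimethoxyphenyl group, so this change has not been tested directly. The closest evidence is methoxy in place of hydrogen on an aromatic carbon, which gives a 1.1-fold lower number from compound 1 to compound 2 (0.03 log units; within the scatter) and a 1.2-fold lower number from compound 1 to compound 3 (0.07 log units; within the scatter). Replacing 3-methoxyphenyl with 2-methoxyphenyl gives a 1.1-fold lower number from compound 2 to compound 3 (0.04 log units; within the scatter). All three steps stay within the scatter, so no step beyond the scatter is expected in this assay, and the direction is left open. The expected step is a 1.0-fold higher number from compound 3 to compound 4 (0.02 log units; within the scatter). The three measured compounds cover only a narrow span, so the range is kept wider than that span. The estimate for compound 4 is 24000 nM, with an expected range of 13000 nM to 42000 nM.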

Compound 4, half-maximal inhibitory concentration: 29200 nM
The estimate for compound 4 lay 1.2-fold (0.09 log units) below the measured number, within the range that was stated.
By their numbers in this assay, from the lowest: compounds 3, 2, 1 and 4 (each within the scatter of the next).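

Among the compounds shown here, the 3,4-dimethoxyphenyl group is the first at this place to carry two methoxy groups, and in this assay it still does not separate from the groups before it: a 1.3-fold higher number from compound 3 to compound 4 (0.10 log units; within the scatter) against 2-methoxyphenyl and a 1.1-fold higher number from compound 1 to compound 4 (0.04 log units; within the scatter) against phenyl, both within the scatter. Adding a second methoxy in place of hydrogen on an aromatic carbon to the single methoxy of the 3-methoxyphenyl group gives a 1.2-fold higher number from compound 2 to compound 4 (0.06 log units; within the scatter), so this change also stays within the scatter when a methoxy is already present. The same change therefore reads alike from phenyl and from 3-methoxyphenyl, and no dependence on the starting group can be read from these four compounds: the same change on two cores in this assay, a 1.2-fold lower number (0.07 log units; within the scatter) from compound 1 to compound 3 and a 1.2-fold higher number (0.06 log units; within the scatter) from compound 2 to compound 4, 1.3-fold (0.13 log units) apart, within the scatter of two such steps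

All four compounds share one core and differ only in phenyl groups with or without methoxy on the saturated chain carbon bound to an aromatic nitrogen, so the series shows no substituent at this place that moves the number beyond the scatter. As far as these compounds go, whether an amine, a carboxylic acid or a longer chain at this place would do so remains open, as does how changes to the shared core would read in this assay.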